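A Methyl Two Bonds Along the Chain from Sulfur

This account rests on a few compounds, and the source may have more. Where it says the series, first, only, none or still open, it means among the compounds named here.

Compound 1 `CCCCSc1nc(Cc2c(F)cccc2Cl)c(C)c(=O)[nH]1`: > 73000 nM
Compound 2 `CCCCSc1nc(C(C)c2c(F)cccc2Cl)c(C)c(=O)[nH]1`: > 1500 nM
Compound 3 `Cc1c(O)nc(SC(C)C)nc1C(C)c1c(F)cccc1F`: > 3000 nM

In an ADME assay on MT4 cells (Homo sapiens) for activation, read by MTT assay (a higher number here means that more compound is tolerated, a lower number that less compound is tolerated), compound 1 gives > 73000 nM, which is a limit of the assay. In this assay compound 2 gives > 1500 nM, also a limit. In this assay compound 3 gives > 3000 nM, again a limit. The change between the first two is methyl in place of hydrogen on a saturated chain carbon bound to two aromatic carbons, and the step that the two limits leave unreadable from compound 1 to compound 2 cannot be read from two limits. How the core of compound 3 differs from that of compound 1 is not broken down here. Compound 4 `CCC(C)Sc1nc(O)c(C)c(C(C)c2c(F)cccc2F)n1` arises from compound 3 through (methyl in place of hydrogen on a saturated chain carbon, two bonds along the chain from a sulfur), the same kind of change at a different place: on a saturated chain carbon, two bonds along the chain from a sulfur, rather than on a saturated chain carbon bound to two aromatic carbons. Compound 4 is expected at 20000 nM in this assay, an estimated step that the limit leaves unreadable from compound 3 to compound 4. That expectation rests on compound 3 sitting at the limit of > 3000 nM in this assay, at which 1 of the 3 values shown sits.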

Compound 4, half-maximal cytotoxic concentration: > 3000 nM
Compound 4: only a limit was reported; the forecaster's own chance of this, stated with the estimate: 60%; the middle value does not contradict the limit.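

Compound 3 and compound 4 both stand only as limits of the assay, and no step can be read between them. The compounds shown leave open whether methyl in place of hydrogen at this place changes the tolerated concentration in this assay at all.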